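Fluoro in the Ortho Position of a Phenyl Substituent

The source may report more compounds than this note shows. Statements on the series, on what has been measured and on what is new or still open speak of the compounds shown alone.

Measured compounds:
compound 1 `c1ccc(-c2cn3ccnc3c(-c3ccc4ncn(C5CCCCC5)c4c3)n2)cc1` — 37.8%
compound 2 `Brc1ccc(-c2cn3ccnc3c(-c3ccc4ncn(C5CCCCC5)c4c3)n2)cc1` — 13.2%
compound 3 `COc1ccccc1-c1cn2ccnc2c(-c2ccc3ncn(C4CCCCC4)c3c2)n1` — 9.62%

In a functional assay on NCI-H460 cells (Homo sapiens) for inhibition, read by sulforhodamine B assay, with a stated time of 48 h, tested at 10 uM (a higher number here means more inhibition at the concentration tested (going by the name of the read-out), a lower number less inhibition), compound 1 gives the highest of the three numbers; its nearest neighbour is compound 2, and compound 3 lies furthest away. Two steps from compound 1 have been measured, both placing a group on the phenyl ring: a number 24.6 percentage points lower from compound 1 to compound 2 (beyond the scatter), and a number 28.2 percentage points lower from compound 1 to compound 3 (beyond the scatter). Between compound 2 and compound 3 the step is within the scatter a number 3.6 percentage points lower from compound 2 to compound 3 (within the scatter).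

Compound 4 `Fc1ccccc1-c1cn2ccnc2c(-c2ccc3ncn(C4CCCCC4)c3c2)n1` differs from compound 1 by fluoro in place of hydrogen on an aromatic carbon. Both measured substitutions of a hydrogen on this ring, bromo and methoxy, lowered the number by a modest amount beyond the scatter, so a downward step is expected for fluoro as well, estimated at a number 17.8 percentage points lower from compound 1 to compound 4 (beyond the scatter) in this assay. The estimate for compound 4 is therefore 20%, with a range from 5% to 38%.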

Compound 4, a percentage reported as inhibition, at one concentration (the size of the read-out at that concentration, not a potency): 8.1%
Estimate against measurement, compound 4: 11.9 percentage points above; low and high end bracket the measured number.
By their numbers in this assay, from the lowest: compounds 4, 3 and 2 (each within the scatter of the next); then compound 1.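

With fluoro on the phenyl ring of compound 1, this assay again falls beyond the scatter (a number 29.7 percentage points lower from compound 1 to compound 4 (beyond the scatter)), so even a single fluorine atom in this place, ortho to a large group, is enough for the loss already seen with bromo and methoxy. Compound 4 cannot be told apart from compound 3 (a number 1.5 percentage points lower from compound 3 to compound 4 (within the scatter)), so exchanging methoxy for fluoro at this position makes no readable difference. Nor can it be told apart from compound 2 (a number 5.1 percentage points lower from compound 2 to compound 4 (within the scatter)), which leaves compound 1, with its unsubstituted phenyl, alone above the three substituted compounds.

Going by these compounds, whether an amine or a hydroxyl group on this ring would also lower the number remains open. So does whether fluoro elsewhere on the ring would behave like 2-fluorophenyl.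

No measured evidence here accounts for these results.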